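Methoxy for Methyl on a Shared Bicyclic Core

The compounds below may be only part of what the source reports. "The series", "measured", "known", "first", "only" and "open" are said of these compounds alone.

Measured compounds:
compound 1 `Cc1ccc(-c2nc3ncccc3o2)cc1` — 5%
compound 2 `Fc1ccc(-c2nc3cccnc3o2)cc1` — 27%
compound 3 `COc1cccc(-c2nc3ncccc3o2)c1` — 14%

In a functional assay on the whole organism for inhibition, with Rattus norvegicus as the target, at a dose of 30 mg/kg (on this read-out lower numbers stand for less inhibition and higher numbers for more inhibition at the one dose given (going by the name of the read-out)), compound 1 gives 5%, the lowest of the three numbers shown. Its gap to compound 3, which gives 14%, lies within the usual scatter of such measurements, so no order between these two can be read. Its gap to compound 2, which gives 27%, lies beyond the scatter, and compound 2 also carries a different arrangement of the shared core, so the two differences cannot be separated.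

Compound 4 `COc1ccc(-c2nc3ncccc3o2)cc1` has not been measured. Compared with compound 1 the change is methoxy in place of methyl on an aromatic carbon. Within the data shown here, no measured pair shows this step alone, and the only methoxy compound, compound 3, carries the group at another place. On that basis a step from compound 1 to compound 4 of a number 7 percentage points higher from compound 1 to compound 4 (within the scatter) is expected, that is, none clearly beyond the scatter. Compound 4 is therefore estimated at 12%, within a range of 0% to 30%.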

Compound 4, a percentage reported as inhibition, in the whole organism at one dose (the size of the read-out at that dose, not a potency): 14%
Compound 4: middle estimate off by 2 percentage points, on the low side; measured number inside the range.
By their numbers in this assay, from the lowest: compounds 1, 3 and 4 (each within the scatter of the next); then compound 2.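

Methoxy in place of methyl on this aromatic carbon, para to a group of 9 heavy atoms, gives in this assay a number 9 percentage points higher from compound 1 to compound 4 (within the scatter) and so cannot be told from no change at this position. The earlier compounds shown here held no pair showing this step alone; now compound 3, with methoxy at another place, gives 14% and compound 4 gives 14% as well, so these two values show no difference between the two places. No measurement shown here offers a reason for this result.

From the compounds shown here alone, whether another group on this carbon, such as an amine, a carboxylic acid or a longer chain, would move the number beyond the scatter remains open. Also open, going by these compounds, is whether the fluorine of compound 2 or its different arrangement of the shared core goes with its 27% in this assay.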